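A few compounds are considered here, and "the series" means these few. Any claim that something is new, unique, unknown or untested is made for them only; others in the source may bear on it.

Measured so far in an ADME assay on HeLa Rh cells (Homo sapiens) for cytotoxicity, read by microscopy; on this read-out lower numbers stand for higher toxicity in this test and higher numbers for lower toxicity in this test:

Compound 1, `COc1cc(CC(O)c2ccc(-c3cccc(C#N)c3)cc2)c([N+](=O)[O-])cc1OC`, gives 5200 nM.
Compound 2, `COc1cc(CC(O)c2ccc(-c3cccc(F)c3)cc2)c([N+](=O)[O-])cc1OC`, gives 7400 nM.
Compound 3, `COc1cc(CC(O)c2ccc(-c3ccccc3C#N)cc2)c([N+](=O)[O-])cc1OC`, gives 9300 nM.

Compound 3 differs from compound 1 in its core by 2-cyanophenyl in place of 3-cyanophenyl on an aromatic carbon, and the step is a 1.8-fold higher number from compound 1 to compound 3 (0.25 log units; within the scatter). Compound 2 differs from compound 1 by fluoro in place of cyano on an aromatic carbon, a change that gives a 1.4-fold higher number from compound 1 to compound 2 (0.15 log units; within the scatter). Compound 4, `COc1cc(CC(O)c2ccc(-c3ccccc3F)cc2)c([N+](=O)[O-])cc1OC`, has not been measured; it differs from compound 3 by fluoro in place of cyano on an aromatic carbon. This is the same kind of change as that from compound 1 to compound 2, but not the same: there the fluoro sits meta to a large group, here ortho to a large group. Since compound 1 to compound 2 gave a 1.4-fold higher number from compound 1 to compound 2 (0.15 log units; within the scatter), a step of a 1.3-fold higher number from compound 3 to compound 4 (0.11 log units; within the scatter) is expected from compound 3 to compound 4 in this assay. Compound 4 is therefore estimated at 12000 nM, between 6000 nM and 24000 nM.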

Compound 4, half-maximal cytotoxic concentration: 5000 nM
For compound 4 the middle estimate is 2.4-fold (0.38 log units) above the measured one; the whole stated range lies above it.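

In this assay fluoro in place of cyano gives a 1.9-fold lower number from compound 3 to compound 4 (0.27 log units; within the scatter) while 2-fluorophenyl gives a 1.5-fold lower number from compound 2 to compound 4 (0.17 log units; within the scatter) in place of 3-fluorophenyl and a 1.0-fold lower number from compound 1 to compound 4 (0.02 log units; within the scatter) in place of 3-cyanophenyl . Set beside the same change on the other core, the new step cannot be told apart from the earlier one: the same change on two cores in this assay, a 1.4-fold higher number (0.15 log units; within the scatter) from compound 1 to compound 2 and a 1.9-fold lower number (0.27 log units; within the scatter) from compound 3 to compound 4, 2.6-fold (0.42 log units) apart, within the scatter of two such steps. So on both cores this change stays within the scatter, but that does not show that it acts alike on the two, as steps this small could hide a real difference.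

Still open, on these data alone, is whether another group at this place, such as an amine or a carboxylic acid, would give a step beyond the scatter.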